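Hydrazone series: ring substituent change at the aryl amine

This account rests on a few compounds, and the source may have more. Where it says the series, first, only, none or still open, it means among the compounds named here.

Measured so far:
compound 1 `CC1CC/C(=N\Nc2ccccc2)c2ncc(CC(=O)O)c(=O)n21` — 100 umol/kg
compound 2 `CC1CC/C(=N\Nc2ccccc2F)c2ncc(C(=O)O)c(=O)n21` — 5 umol/kg
compound 3 `CC1CC/C(=N\Nc2ccc(F)cc2)c2ncc(C(=O)O)c(=O)n21` — 12.2 umol/kg

In a functional assay on the whole organism for inhibition, with Rattus norvegicus as the target (on this read-out lower numbers stand for an effect already at smaller amounts and higher numbers for an effect only at larger amounts of compound), compound 3 stands second highest of the three numbers; its nearest neighbour is compound 2, the furthest compound 1, whose value is the highest of the set. For the measured compounds named here, the one step between directly comparable compounds, a 2.4-fold higher number from compound 2 to compound 3 (0.39 log units; beyond the scatter), is the only measured change on the aryl ring and it is modest.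

Compound 4 `CC1CC/C(=N\Nc2cccc(Cl)c2)c2ncc(C(=O)O)c(=O)n21` differs from compound 3 in one place: 3-chlorophenyl in place of 4-fluorophenyl on an amine nitrogen. This change moves the halogen to a different ring position and exchanges fluorine for chlorine at the same time. Going by the values given here, the measured step from compound 2 to compound 3 shows that a position change of the halogen alone shifts the number by a modest amount in this assay; it gives no guide for chlorine in place of fluorine, and no compound with a 3-substituted ring has been measured. Compound 1 belongs to a different acid and does not bear on this step.

The expected step of a 1.2-fold lower number from compound 3 to compound 4 (0.09 log units; within the scatter) is therefore small and of uncertain direction. Compound 4 is estimated at 10 umol/kg, within 3 umol/kg to 30 umol/kg.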

Compound 4, dose for 50% inhibition: 0.6 umol/kg
The estimate for compound 4 lay 17-fold (1.22 log units) above the measured number, and the stated range ends above it.
By their numbers in this assay, from the lowest: compound 4; then compound 2; then compound 3; then compound 1.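

In this assay, the aryl group on the amine nitrogen has far more influence than the earlier ring comparison could show: a 2.4-fold higher number from compound 2 to compound 3 (0.39 log units; beyond the scatter) was a modest step, whereas 3-chlorophenyl in place of 4-fluorophenyl gives a 20-fold lower number from compound 3 to compound 4 (1.31 log units; beyond the scatter), a large one. The same group in place of 2-fluorophenyl gives an 8.3-fold lower number from compound 2 to compound 4 (0.92 log units; beyond the scatter), so compound 4 lies beyond the scatter below both fluorophenyl compounds, and neither fluorine placement measured so far matches it. Both steps change the halogen and its ring position together, and nothing shown accounts for their size.

As far as these compounds go, the share of the gain belonging to chlorine and the share belonging to its position remain open; a chlorophenyl carrying chlorine where compound 3 carries fluorine, and a fluorophenyl carrying fluorine where compound 4 carries chlorine, would separate the two. Also open, from the compounds shown here alone, is whether the gain is specific to halogen, which a methoxy or trifluoromethyl group in place of the chlorine of compound 4 would test, with plain phenyl on the same core as the reference.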